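The compounds below may be only part of what the source reports. "The series", "measured", "known", "first", "only" and "open" are said of these compounds alone.

Compound 1 `O=C(CSc1nc(Nc2ccccc2)c2ccccc2n1)Nc1ccccc1Br` gives 19800 nM in a functional assay on PC-3 cells (Homo sapiens) for inhibition, read by MTT assay, with a stated time of 72 h; a higher number here means a weaker inhibitor, a lower number a stronger inhibitor.
Compound 2 `O=C(CSc1nc(Nc2ccccc2)c2ccccc2n1)Nc1cccc(F)c1` gives 15600 nM.
Compound 3 `O=C(CSc1nc(Nc2ccccc2)c2ccccc2n1)Nc1cccc([N+](=O)[O-])c1` gives 11800 nM.

Compound 3 shows the smallest of the three numbers, but its gaps to compound 1 and compound 2 are within the scatter of this assay, so the three cannot be told apart. Compound 4 `C=CC(=O)Nc1cccc(NC(=O)CSc2nc(Nc3ccccc3)c3ccccc3n2)c1` differs from compound 3 by (vinylcarbonyl)amino in place of nitro on an aromatic carbon. The step that touched the same carbon was a 1.3-fold lower number from compound 2 to compound 3 (0.12 log units; within the scatter); the other swaps on the amide-bound ring, a 1.3-fold lower number from compound 1 to compound 2 (0.10 log units; within the scatter) and a 1.7-fold lower number from compound 1 to compound 3 (0.22 log units; within the scatter), were also within the scatter. Every change on that ring so far has left the number essentially unmoved, so no step beyond the scatter is expected here, a 1.2-fold lower number from compound 3 to compound 4 (0.09 log units; within the scatter). Compound 4 is therefore estimated at 9500 nM, with a range from 3000 nM to 30000 nM.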

Compound 4, half-maximal inhibitory concentration: 8740 nM
Compound 4: the middle estimate sits 1.1-fold (0.04 log units) above what was measured; the range from low to high includes it.
By their numbers in this assay, from the lowest: compounds 4, 3, 2 and 1 (each within the scatter of the next, the first and the last beyond it).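

In this assay the (vinylcarbonyl)amino group, which carries a hydrogen-bond donor that nitro lacks, can stand on this aromatic carbon without a clear change, with a 1.4-fold lower number from compound 3 to compound 4 (0.13 log units; within the scatter) and a 1.8-fold lower number from compound 2 to compound 4 (0.25 log units; within the scatter). Going by these compounds alone, the first step on this ring to pass the scatter, and only modestly, is a 2.3-fold lower number from compound 1 to compound 4 (0.36 log units; beyond the scatter), which replaces the whole 2-bromophenyl with 3-((vinylcarbonyl)amino)phenyl. No supporting evidence is available to explain these results. As far as these compounds go, whether an amine or a longer chain on the same carbon would move the number further remains open.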